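Swapping a thiazole for a pyridine N-oxide on a piperidine

The compounds below may be only part of what the source reports. "The series", "measured", "known", "first", "only" and "open" are said of these compounds alone.

Measured so far:
compound 1 `CCc1cccc(NC(=O)CN2CCC(c3cccc[n+]3[O-])CC2)c1` gives 62%
compound 2 `Cc1cccc(C(=O)NCN2CCC(c3nccs3)CC2)c1` gives 71%
compound 3 `Cc1cccc(NC(=O)CN2CCC(c3cccc(F)c3)CC2)c1` gives 40%

In a functional assay on HEK293 cells for agonist activity at D(4) dopamine receptor (Homo sapiens), read by FLIPR (on this read-out higher numbers stand for larger maximal responses and lower numbers for smaller maximal responses), compound 2 and compound 1 lie within the usual scatter of each other, so no order between them can be read, while compound 3 lies beyond the scatter, lower than compound 2. The untested compound 4 `Cc1cccc(C(=O)NCN2CCC(c3cccc[n+]3[O-])CC2)c1` differs from compound 2 in one place: a group of 7 heavy atoms (5 carbon, 1 nitrogen, 1 oxygen; one six-membered aromatic ring with 1 hetero atom) in place of a group of 5 heavy atoms (3 carbon, 1 nitrogen, 1 sulfur; one five-membered aromatic ring with 2 hetero atoms), on a saturated ring carbon. Among the compounds with values here, no measured pair shows this change directly. The entering group is already present in compound 1, which gives 62% in this assay, so only a small change, if any, is expected from the step of a number 7 percentage points lower from compound 2 to compound 4 (within the scatter). Compound 4 is therefore estimated at 64%, within a range from 45% to 82%.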

Compound 4, largest response reached (reported as efficacy), in percent of the reference or control that the assay uses: 77%
For compound 4 the middle estimate is 13 percentage points below the measured one; low and high end bracket the measured number.
By their numbers in this assay, from the lowest: compound 3; then compounds 1, 2 and 4 (each within the scatter of the next, the first and the last beyond it).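

The step of a number 6 percentage points higher from compound 2 to compound 4 (within the scatter) comes from replacing the 1,3-thiazol-2-yl group with the pyridine N-oxide on a saturated ring carbon, as read in this assay. For this pair, then, the five-membered and six-membered aromatic rings cannot be told apart at this position, although they differ in ring size and hetero atoms. Nothing shown gives a reason for this. On these data alone, it remains open how an amine or a carboxylic acid at this ring carbon would behave. Also open, as far as these compounds go, is whether the thiazole and the N-oxide would again match on the core of compound 1.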